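Compound 2 to compound 3: methoxy for bromo

A few compounds are considered here, and "the series" means these few. Any claim that something is new, unique, unknown or untested is made for them only; others in the source may bear on it.

Of the compounds shown here, two have numbers so far. In a functional assay on HepG2 cells (Homo sapiens) for antiproliferative activity, read by MTT assay (a lower number here means a stronger inhibitor, a higher number a weaker inhibitor), compound 1 (`COc1ccc(-c2ccnc(Nc3ccc([N+](=O)[O-])cc3)n2)cc1`) gives 1040 nM and compound 2 (`Clc1ccc(Nc2nccc(-c3ccc(Br)cc3)n2)cc1`) gives 47500 nM as the higher number of the two. That gap lies beyond the scatter, which makes compound 2 the weaker inhibitor of the pair.

Compound 3 (`COc1ccc(-c2ccnc(Nc3ccc(Cl)cc3)n2)cc1`) departs from compound 2 by methoxy in place of bromo on an aromatic carbon, para to a large group (methoxy in place of bromo on an aromatic carbon). For the measured compounds named here, no measured pair isolates this change, so the expectation is tentative. It rests on compound 1, which also carries methoxy and stands at 1040 nM in this assay as the lower number. A move to a lower number, beyond the scatter, is expected: the estimated step is a 5.9-fold lower number from compound 2 to compound 3 (0.77 log units; beyond the scatter) (covering only part of the gap). Compound 3 is estimated at 8000 nM (range 1500 nM to 40000 nM).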

Compound 3, half-maximal inhibitory concentration: 4500 nM
Compound 3: the middle estimate sits 1.8-fold (0.25 log units) above what was measured; low and high end bracket the measured number.
By their numbers in this assay, from the lowest: compound 1; then compound 3; then compound 2.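

In this assay, methoxy in place of bromo on an aromatic carbon, para to a large group, gives an 11-fold lower number from compound 2 to compound 3 (1.02 log units; beyond the scatter). For the compounds shown here, this is the first reading that isolates this position, and the large step shows that the number responds strongly to this exchange while the chloro group stays fixed. With methoxy held constant, chloro in place of nitro on an aromatic carbon gives a 4.3-fold higher number from compound 1 to compound 3 (0.64 log units; beyond the scatter), a modest step showing that the second substituted site also shifts the number. Nothing available explains either step.

As far as these compounds go, whether the methoxy-for-bromo step keeps its size with nitro in place of chloro remains open. Also open, from the compounds shown here alone, is how an amine, a hydroxyl group or a longer alkoxy chain would compare with methoxy at this position.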